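The source may report more compounds than this note shows. Statements on the series, on what has been measured and on what is new or still open speak of the compounds shown alone.

In a functional assay on BXPC-3 cells (Homo sapiens) for antiproliferative activity, read by sulforhodamine B assay, with a stated time of 72 h (a higher number here means a weaker inhibitor, a lower number a stronger inhibitor), compound 1 `CC(C)(C)c1[nH]cnc1/C=c1\[nH]c(=O)/c(=C/c2cccc(C(=O)N3CCCC3)c2)[nH]c1=O` gives 325 nM, while compound 2 `CC(C)(C)c1[nH]cnc1/C=c1\[nH]c(=O)/c(=C/c2cccc(C(=O)N3CCCCC3)c2)[nH]c1=O` gives 100 nM, the lower of the two numbers. Compound 3 `CC(C)(C)c1[nH]cnc1/C=c1\[nH]c(=O)/c(=C/c2cccc(C(=O)c3cccnc3)c2)[nH]c1=O` has pyridin-3-yl in place of piperidin-1-yl on a carbonyl carbon. Among the compounds with values here, the only measured guide is a change at this same carbonyl carbon, a 3.3-fold lower number from compound 1 to compound 2 (0.51 log units; beyond the scatter). Within the data shown here, no measured compound has an aromatic ring there, so the guide is weak, but a modest further drop is expected. The expected step is a 2.5-fold lower number from compound 2 to compound 3 (0.40 log units; beyond the scatter). For compound 3 the estimated value is 40 nM, with an expected range from 8 nM to 200 nM.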

Compound 3, half-maximal inhibitory concentration: 4.05 nM
The estimate for compound 3 lay 9.9-fold (0.99 log units) above the measured number; measured number outside the range, below it.
By their numbers in this assay, from the lowest: compound 3; then compound 2; then compound 1.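

Replacing piperidin-1-yl with pyridin-3-yl on this carbonyl carbon in this assay gives a 25-fold lower number from compound 2 to compound 3 (1.39 log units; beyond the scatter), and replacing pyrrolidin-1-yl gives an 80-fold lower number from compound 1 to compound 3 (1.90 log units; beyond the scatter). Both steps are large, so this position responds far more strongly than the two non-aromatic rings alone showed. The groups in compound 2 and compound 3 hold the same number of heavy atoms, but the pyridin-3-yl ring is aromatic and carries a hydrogen-bond acceptor, and no measurement here explains the gain. The compounds shown cannot separate the aromatic ring from its nitrogen. A phenyl group on the same carbonyl carbon would test that.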